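Pyrrolidin-1-yl in place of triazolyl at compound 4

A few compounds are considered here, and "the series" means these few. Any claim that something is new, unique, unknown or untested is made for them only; others in the source may bear on it.

Three compounds on one shared core have numbers in an assay on HEK293 cells for agonist activity at Toll-like receptor 8 (Homo sapiens), read by spectrophotometry; on this read-out lower numbers stand for an effect already at smaller amounts and higher numbers for an effect only at larger amounts of compound. Compound 1 `CCCCNc1nc(N)nc(C)c1CCC(C)(C)O` gives 3140 nM, compound 2 `CCCCNc1nc(N)nc(C)c1CCCN1CCCCCC1` gives 178 nM, and compound 3 `CCCCNc1nc(N)nc(C)c1CCCn1cncn1` gives 1050 nM. Compound 3 thus holds the second highest of the three numbers, nearest to compound 1 and furthest from compound 2. The steps reaching it are a 3.0-fold lower number from compound 1 to compound 3 (0.48 log units; beyond the scatter) and a 5.9-fold higher number from compound 2 to compound 3 (0.77 log units; beyond the scatter). Compound 4 `CCCCNc1nc(N)nc(C)c1CCCN1CCCC1` differs from compound 3 by pyrrolidin-1-yl in place of 1H-1,2,4-triazol-1-yl on a saturated chain carbon, three bonds along the chain from an aromatic carbon. Among the measured compounds shown here, the step that bears on this change is the one from compound 2, whose azepan-1-yl, like pyrrolidin-1-yl, is a non-aromatic ring with one hetero atom; that step read a 5.9-fold higher number from compound 2 to compound 3 (0.77 log units; beyond the scatter). Going back from the triazolyl to such a ring is therefore expected to lower the number beyond the scatter, though the smaller ring may not fully recover the number of compound 2. The expected step is a 3.3-fold lower number from compound 3 to compound 4 (0.52 log units; beyond the scatter) in this assay. Compound 4 is estimated at 320 nM, within a range from 110 nM to 950 nM.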

Compound 4, half-maximal effective concentration: 110 nM
Beside the measured number, compound 4's estimate is 2.9-fold (0.46 log units) above it; low and high end bracket the measured number.
By their numbers in this assay, from the lowest: compounds 4 and 2 (each within the scatter of the next); then compound 3; then compound 1.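

Working notes: in this assay, with the ring kept five-membered, a 9.5-fold lower number from compound 3 to compound 4 (0.98 log units; beyond the scatter) is the first direct read of an aromatic ring with 3 hetero atoms against a non-aromatic ring with 1 hetero atom at this place on the chain. The step of a 1.6-fold lower number from compound 2 to compound 4 (0.21 log units; within the scatter) shows that pyrrolidin-1-yl and azepan-1-yl are not separated here, while a 29-fold lower number from compound 1 to compound 4 (1.46 log units; beyond the scatter) is the largest step in the set and places the pyrrolidin-1-yl side chain well apart from the 1-hydroxy-1-methylethyl side chain. No supporting measurement accounts for any of these steps.

Still open, going by these compounds, is whether a morpholin-4-yl ring or an open-chain diethylamino group at this place would fall with compound 4 or with compound 3. Also open, on these data alone, is how a longer chain carrying the pyrrolidin-1-yl would read.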